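This account rests on a few compounds, and the source may have more. Where it says the series, first, only, none or still open, it means among the compounds named here.

Measured so far in a toxicity assay on KB cells (Homo sapiens) for cytotoxicity, read by fluorescence, with a stated time of 3 days; a lower number here means that less compound is needed, a higher number that more compound is needed for the effect:
- compound 1 `CCCCOC(=O)CNC(=O)[C@H](CSc1ccc([N+](=O)[O-])cc1[N+](=O)[O-])NC(=O)CC[C@H](Nc1ccc([N+](=O)[O-])cc1[N+](=O)[O-])C(=O)OCCCC`: > 300 uM, a limit of the assay
- compound 2 `CCCCOC(=O)CNC(=O)[C@H](CSc1ccc([N+](=O)[O-])cc1[N+](=O)[O-])NC(=O)CC[C@H](NC(=O)OC)C(=O)OCCCC`: > 300 uM, again a limit of the assay

Within the data shown here, compound 2 therefore stands not on a number but on the limit of this assay, and the only comparison available, a step that the two limits leave unreadable from compound 1 to compound 2, is left unreadable because both values sit at the limit of > 300 uM in this assay, at which 2 of the 2 values shown sit. Among the measured compounds shown here, no measured step has a readable size.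

Compound 3 `CCCCOC(=O)CNC(=O)[C@H](CSc1ccc([N+](=O)[O-])cc1[N+](=O)[O-])NC(=O)CC[C@H](NC(=O)CCC(C)C)C(=O)OCCCC` differs from compound 2 in one place: isopentyl in place of methoxy on a carbonyl carbon. The amide-type nitrogen carrying the changed group is unchanged, and the rest of the shared core is kept as in compound 2.

For the measured compounds named here, nothing measured bears on this change in a readable way; the one step known is unreadable, and compound 2 itself shows only the limit. The expectation rests on that standing alone: compound 3 is expected to show no readable step, a number no higher from compound 2 to compound 3 (the limit leaves the size open), and most likely to remain at the limit. The estimate for compound 3 in this assay is 300 uM, with a range from 150 uM to 1000 uM.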

Compound 3, concentration for half-maximal effect: 84 uM
Compound 3: middle estimate off by 3.6-fold (0.55 log units), on the high side; measured number outside the range, below it.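

In this assay the group on the carbonyl carbon whose other neighbour is the amide-type nitrogen gives the first readable result of the series, with isopentyl in place of methoxy producing an at least 3.5-fold lower number from compound 2 to compound 3 (0.55 log units; beyond the scatter). The substituent on the amine nitrogen can now also be read, with isopentylcarbonyl in place of 2,4-dinitrophenyl producing an at least 3.5-fold lower number from compound 1 to compound 3 (0.55 log units; beyond the scatter), whereas the step with methoxycarbonyl in place of 2,4-dinitrophenyl cannot be read. Both readable steps start from a limit of the assay and not from a number, so their full size stays open because of the position of those two starting values: the limit of > 300 uM in this assay, at which 2 of the 3 values shown sit.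

The compounds shown leave open whether the isopentyl chain itself carries the step, or whether a shorter chain, a longer chain or a phenyl ring on the same carbonyl carbon would give a similar number in this assay. They also leave open whether an amine or a carboxylic acid at the end of such a chain would keep the number readable or return it to the limit.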